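Swapping the Acid Tail for a Hydroxamic Acid Arm

The source may report more compounds than this note shows. Statements on the series, on what has been measured and on what is new or still open speak of the compounds shown alone.

Among the measured compounds shown here, compound 2 `O=C(O)CCCCCOc1ccc2cc1COC/C=C/COCc1cccc(c1)-c1ccnc(n1)N2` gives 41000 nM in a functional assay on HCT-116 cells (Homo sapiens) for antiproliferative activity, read by MTT assay, with a stated time of 72 h (a lower number here means a stronger inhibitor, a higher number a weaker inhibitor), the higher of the two numbers measured so far, while compound 1 `O=C(O)CCCCCCOc1ccc2cc1COC/C=C/COCc1cccc(c1)-c1ccnc(n1)N2` gives 6060 nM. For the measured compounds named here, the only measured step, a 6.8-fold higher number from compound 1 to compound 2 (0.83 log units; beyond the scatter), is a modest one. Compound 3 `O=C(NO)c1ccc(NCCOc2ccc3cc2COC/C=C/COCc2cccc(c2)-c2ccnc(n2)N3)cc1` carries a far larger change: (4-(hydroxycarbamoyl)phenyl)amino in place of 3-carboxypropyl on a saturated chain carbon, two bonds along the chain from an oxygen on an aromatic ring. Going by the values given here, no measured step covers a swap of this kind, so the single known step is only a loose guide, but a shift bigger than that step seems plausible. Compound 3 is expected to give 2500 nM, between 300 nM and 20000 nM, an estimated step of a 16-fold lower number from compound 2 to compound 3 (1.21 log units; beyond the scatter).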

Compound 3, half-maximal inhibitory concentration: 3200 nM
Beside the measured number, compound 3's estimate is 1.3-fold (0.11 log units) below it; the measured number falls inside the stated range.
By their numbers in this assay, from the lowest: compounds 3 and 1 (each within the scatter of the next); then compound 2.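

In this assay the step of a 13-fold lower number from compound 2 to compound 3 (1.11 log units; beyond the scatter) is large and shows that this saturated chain carbon can carry (4-(hydroxycarbamoyl)phenyl)amino, with its six-membered aromatic ring, in place of 3-carboxypropyl. Set against 4-carboxybutyl, the same group gives a 1.9-fold lower number from compound 1 to compound 3 (0.28 log units; within the scatter) and cannot be told apart from that longer acid tail. Nothing measured here explains either step.

The compounds shown leave open whether the gain over compound 2 comes from the hydroxamic acid or from the aromatic ring and its amine. A carboxylic acid on that same ring, in place of the hydroxycarbamoyl group, would separate the two.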